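The compounds below may be only part of what the source reports. "The series", "measured", "known", "first", "only" and "open" are said of these compounds alone.

Compound 1 `N=C(N)N/N=C/c1c(-c2ccsc2)nc2sccn12` and compound 2 `Cc1cc(-c2nc3sccn3c2/C=N/NC(=N)N)c(C)s1` share one core, while compound 3 `N=C(N)N/N=C/c1c(-c2ccsc2)nc2n1CCS2` and compound 4 `Cc1cc(-c2nc3n(c2/C=N/NC(=N)N)CCS3)c(C)s1` share a second one; how the two cores differ is not broken down here. In a functional assay on cells (Cancer cell lines, Homo sapiens) for inhibition (a lower number here means a stronger inhibitor of growth, a higher number a weaker inhibitor of growth), compound 1 gives 15500 nM, and in this assay compound 2 gives 17400 nM. The two are joined by 2,5-dimethylthiophen-3-yl in place of thiophen-3-yl on an aromatic carbon, and that change made a 1.1-fold higher number from compound 1 to compound 2 (0.05 log units; within the scatter). In this assay compound 3 gives 14500 nM, a number that sits alongside those of compound 1 and compound 2 with no separation that the scatter would allow to be read as order.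

Compound 4 has not yet been tested. It is separated from compound 3 by 2,5-dimethylthiophen-3-yl in place of thiophen-3-yl on an aromatic carbon. Among the compounds with values here, this is the same kind of change as the one between compound 1 and compound 2, though not the same: around the place in compound 3 the aromatic carbon is also two ring bonds from two ring atoms that each bear a fused ring, a feature that the place in compound 1 does not share. Within the data shown here, with only one earlier instance, the account of this change rests on the pair compound 1 to compound 2, where the step stayed within the scatter. On that basis the step from compound 3 to compound 4 is expected to be a 1.1-fold higher number from compound 3 to compound 4 (0.04 log units; within the scatter), again within the scatter, beside a 1.1-fold higher number from compound 1 to compound 2 (0.05 log units; within the scatter). Compound 4 is therefore estimated at 16000 nM in this assay, with an expected range from 8000 nM to 32000 nM.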

Compound 4, concentration for 50% growth inhibition: 24000 nM
Beside the measured number, compound 4's estimate is 1.5-fold (0.18 log units) below it; measured number inside the range.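

In this assay, 2,5-dimethylthiophen-3-yl in place of thiophen-3-yl on an aromatic carbon gave a 1.7-fold higher number from compound 3 to compound 4 (0.22 log units; within the scatter), so on this second core the change again stays within the scatter. Set beside the earlier instance, the two steps cannot be told apart, and the change carries from one core to the other without a difference that can be read: the same change on two cores in this assay, a 1.1-fold higher number (0.05 log units; within the scatter) from compound 1 to compound 2 and a 1.7-fold higher number (0.22 log units; within the scatter) from compound 3 to compound 4, 1.5-fold (0.17 log units) apart, within the scatter of two such steps This shows only that, across these two pairs, the change leaves growth inhibition without a readable shift on either core; it does not show that the change has no effect on the cores of other compounds, and two pairs are too few to establish a rule for the series.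

Going by these compounds, all four compounds carry either thiophen-3-yl or 2,5-dimethylthiophen-3-yl at this aromatic carbon, so what a phenyl ring or an amine at that place would do remains open. The group of 6 heavy atoms on the ring is also the same throughout, which leaves open what a carboxylic acid or a longer chain in its place would do to growth inhibition in this assay.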